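Fluoro for hydrogen on two different rings

A few compounds are considered here, and "the series" means these few. Any claim that something is new, unique, unknown or untested is made for them only; others in the source may bear on it.

Three measured compounds share one general build, and their numbers come from a functional assay on HepG2 cells (Homo sapiens) for cytotoxicity, read by MTT assay, with a stated time of 72 h; a lower number here means a stronger inhibitor, a higher number a weaker inhibitor. Compound 1 `Cc1cc(=O)n(-c2ccc(F)cc2)nc1C(=O)Nc1ccc(Oc2ncnc3ccsc23)c(F)c1` gives 470 nM in this assay. Compound 2 `Cc1cc(=O)n(-c2ccc(F)c(F)c2)nc1C(=O)Nc1ccc(Oc2ncnc3ccsc23)c(F)c1` differs from compound 1 in one place only, namely (fluoro in place of hydrogen on an aromatic carbon), and in this assay compound 2 gives 6930 nM. That single change produced a 15-fold higher number from compound 1 to compound 2 (1.17 log units; beyond the scatter).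

Compound 3 `Cc1cc(=O)n(-c2ccccc2C(F)(F)F)nc1C(=O)Nc1ccc(Oc2ncnc3sccc23)cc1` carries a different core; how its core differs from that of compound 1 is not broken down here. In this assay compound 3 yields only a limit, > 40000 nM. This is the limit of > 40000 nM in this assay, at which 1 of the 3 values shown sits.

Compound 4 `Cc1cc(=O)n(-c2ccccc2C(F)(F)F)nc1C(=O)Nc1ccc(Oc2ncnc3sccc23)c(F)c1` has not yet been run. Relative to compound 3 the change is fluoro in place of hydrogen on an aromatic carbon. It is the same kind of change as that from compound 1 to compound 2, not the same change: in compound 2 the entering fluoro sits ortho to a fluoro group and meta to a large group, whereas in compound 4 it sits ortho to a large group and meta to a large group.

Going by the values given here, the only measured precedent for this change is a 15-fold higher number from compound 1 to compound 2 (1.17 log units; beyond the scatter), and compound 3 already shows only a limit in this assay. From compound 3 to compound 4 a step that the limit leaves unreadable from compound 3 to compound 4 is therefore expected, with the direction taken from the precedent rather than from any measured number for compound 3. For compound 4 the estimate in this assay is 80000 nM, most likely reported again as a limit, within an expected range of 25000 nM to 300000 nM.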

Compound 4, half-maximal inhibitory concentration: 14700 nM
Estimate against measurement, compound 4: 5.4-fold (0.74 log units) above, outside the stated range (below it).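

In this assay, fluoro in place of hydrogen on an aromatic carbon gives an at least 2.7-fold lower number from compound 3 to compound 4 (0.43 log units; beyond the scatter), so a step measured on one core does not give the direction of the same kind of change on the other. The two steps run in opposite directions and are clearly separated: the same change on two cores in this assay, a 15-fold higher number (1.17 log units; beyond the scatter) from compound 1 to compound 2 and an at least 2.7-fold lower number (0.43 log units; beyond the scatter) from compound 3 to compound 4, at least 40-fold (1.60 log units) apart, beyond the scatter of two such steps Compound 3 stands only at a limit, > 40000 nM, so the full size of its step stays unread, and the comparison does not show whether the core or the place of the entering fluoro sets the direction, as the two pairs differ in both.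

On these data alone, each core contributes a single pair here, so it remains open whether the fluoro added in compound 2 would raise the number on the core of compound 3, and whether the fluoro added in compound 4 would lower it on the core of compound 1. As far as these compounds go, it is also open whether a chloro group or a methoxy group at the same positions would follow either of the two fluoro steps.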